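Ether linkage replacing the benzyl methylene on the alkyne chain

A few compounds are considered here, and "the series" means these few. Any claim that something is new, unique, unknown or untested is made for them only; others in the source may bear on it.

Compound 1 `C=CC(=O)N1CCC[C@@H](n2nc(C#CCCc3ccccc3)c3c(N)ncnc32)C1` is the parent. In a functional assay on Ramos cells (Homo sapiens) for antiproliferative activity, read by CCK-8 assay, with a stated time of 48 h (a higher number here means a weaker inhibitor, a lower number a stronger inhibitor), compound 1 reaches only the assay limit of > 40000 nM. Compound 2 `C=CC(=O)N1CCC[C@@H](n2nc(C#CCNc3ccccc3)c3c(N)ncnc32)C1` gives 18200 nM in this assay. Among the compounds with values here, the sole measured step, an at least 2.1-fold lower number from compound 1 to compound 2 (0.34 log units; beyond the scatter), is bounded in size because compound 1 sits at the limit of > 40000 nM in this assay, at which 1 of the 2 values shown sits. Compound 3 `C=CC(=O)N1CCC[C@@H](n2nc(C#CCOc3cccc(OC)c3)c3c(N)ncnc32)C1` differs from compound 1 by 3-methoxyphenoxy in place of benzyl on a saturated chain carbon bound to a triple-bonded carbon. Like the measured change, this puts a linking atom into the chain that bore benzyl. A downward step of comparable size is therefore expected, an at least 2.0-fold lower number from compound 1 to compound 3 (0.30 log units; that floor lies within the scatter). Compound 3 is estimated at 20000 nM, within a range from 7000 nM to 45000 nM.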

Compound 3, half-maximal inhibitory concentration: > 40000 nM
Compound 3 ended at the assay's limit; the forecaster's own chance of this, stated with the estimate: 30%; middle value at least 2.0-fold (0.30 log units) from the limit.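

In this assay, the step from anilino to 3-methoxyphenoxy on this chain carbon is an at least 2.1-fold higher number from compound 2 to compound 3 (0.34 log units; beyond the scatter), so a linking atom in the chain does not by itself preserve the lower number of compound 2. Compound 3 gives > 40000 nM, which is a limit of the assay. The step between compound 1 and compound 3 cannot be read: the limit of > 40000 nM in this assay, at which 2 of the 3 values shown sit.

Still open, going by these compounds, is whether the ether oxygen or the methoxy group accounts for the higher number relative to compound 2. Unsubstituted phenoxy and 3-methoxyanilino on this chain carbon would separate the two.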